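Compound 1 loses its (1-bromoethenyl)carbonyl group

A few compounds are considered here, and "the series" means these few. Any claim that something is new, unique, unknown or untested is made for them only; others in the source may bear on it.

Compound 1 `C=C(Br)C(=O)Nc1ccc(/C=C/C(=O)c2ccc(C)cc2)cc1` measures 2100 nM in the assay below
Compound 2 `C=C(Br)C(=O)Nc1ccc(/C=C/C(=O)c2ccc(OC)cc2)cc1` measures 1400 nM in the same assay

Within the data shown here, in a functional assay on HeLa cells (Homo sapiens) for antiproliferative activity, with a stated time of 48 h (a lower number here means a stronger inhibitor, a higher number a weaker inhibitor), compound 1 gives 2100 nM and holds the higher of only two numbers, yet it stays within the scatter of compound 2. Among the measured compounds shown here, the only measured step is a 1.5-fold lower number from compound 1 to compound 2 (0.18 log units; within the scatter) and it concerns methoxy in place of methyl, so it says nothing direct about the change ahead. Compound 3 `Cc1ccc(C(=O)/C=C/c2ccc(N)cc2)cc1` has not been measured. It carries hydrogen in place of (1-bromoethenyl)carbonyl on a nitrogen on an aromatic ring. For the measured compounds named here, both measured compounds hold this group, so no measured pair shows what its loss does. A clear move towards a higher number is nevertheless expected, and the estimated step is a 7.1-fold higher number from compound 1 to compound 3 (0.85 log units; beyond the scatter) with wide uncertainty. For compound 3 the estimate is 15000 nM with an expected range from 4000 nM to 50000 nM in this test.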

Compound 3, half-maximal inhibitory concentration: 40000 nM
Estimate against measurement, compound 3: 2.7-fold (0.43 log units) below, and the stated range covers the measured number.
By their numbers in this assay, from the lowest: compounds 2 and 1 (each within the scatter of the next); then compound 3.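

In this assay, among these compounds, the exchange of (1-bromoethenyl)carbonyl for hydrogen on the nitrogen gives a 19-fold higher number from compound 1 to compound 3 (1.28 log units; beyond the scatter), the first step here that lies beyond the scatter. The position therefore matters in this series: with the core of compound 1 otherwise unchanged, the ((1-bromoethenyl)carbonyl)amino to amino change alone takes the number far upward, which the earlier methoxy for methyl step could not show. Nothing measured here explains this loss.

The compounds shown leave open which part of the lost group matters, the bromine, the double bond or the carbonyl, and whether an acetyl group or a plain acryloyl group on the same nitrogen would keep the number near that of compound 1. They also leave open whether the same loss would have a similar size on the methoxy-bearing compound 2.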